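The source may report more compounds than this note shows. Statements on the series, on what has been measured and on what is new or still open speak of the compounds shown alone.

Measured in a functional assay on MDA-MB-231 cells (Homo sapiens) for antiproliferative activity, read by MTT assay, with a stated time of 72 h; on this read-out higher numbers stand for weaker inhibition and lower numbers for stronger inhibition:
- compound 1 `NC1=NC2(CCOCC2)N(OCCCOc2cccc(Cl)c2Cl)C(N)=N1`: 140 nM
- compound 2 `NC1=NC2(CCSCC2)N(OCCCOc2cccc(Cl)c2Cl)C(N)=N1`: 1 nM

Compound 1 holds the higher number of the two, beyond the scatter from compound 2. Compound 3 `NC1=NC2(CCOCC2)N(OCCCOc2ccccc2Br)C(N)=N1` keeps the core of compound 1 and carries 2-bromophenyl in place of 2,3-dichlorophenyl on an oxygen on a saturated carbon. Among the compounds with values here, no measured pair shows this change, so no step beyond the scatter is expected in this assay, starting from compound 1 at 140 nM. The estimated step is a 1.4-fold higher number from compound 1 to compound 3 (0.15 log units; within the scatter). For compound 3 the expected value is 200 nM, with an estimated range of 40 nM to 1000 nM.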

Compound 3, half-maximal inhibitory concentration: 910 nM
The estimate for compound 3 lay 4.6-fold (0.66 log units) below the measured number, and the stated range covers the measured number.
By their numbers in this assay, from the lowest: compound 2; then compound 1; then compound 3.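

In this assay, 2-bromophenyl in place of 2,3-dichlorophenyl on an oxygen on a saturated carbon gives a 6.5-fold higher number from compound 1 to compound 3 (0.81 log units; beyond the scatter) on the core of compound 1. Within the data shown here, compound 1 and compound 2 both carry 2,3-dichlorophenyl, so this is the first sign that the number responds to a change in this aryl group. Nothing at hand explains the step.

Open, from the compounds shown here alone, is whether 2-chlorophenyl or 3-chlorophenyl would separate the effect of the bromine from that of the chlorines. Also open, going by these compounds, is whether the same change on the core of compound 2 gives a similar step.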